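The source may report more compounds than this note shows. Statements on the series, on what has been measured and on what is new or still open speak of the compounds shown alone.

In a functional assay on MCF7 cells (Homo sapiens) for antiproliferative activity, read by MTT assay, with a stated time of 48 h (on this read-out higher numbers stand for weaker inhibition and lower numbers for stronger inhibition), the three measured compounds read as follows
- compound 1 `CC(=O)N1N=C(c2ccc3ccccc3c2)OC1c1ccccc1` at 2.43 ug/mL
- compound 2 `CC(=O)N1N=C(c2ccc3ccccc3c2)OC1c1ccccc1Cl` at 2.36 ug/mL
- compound 3 `CC(=O)N1N=C(c2ccc3ccccc3c2)OC1c1ccccc1O` at 2.12 ug/mL

Compound 3 at 2.12 ug/mL cannot be told apart from the other two, since its steps to both lie within the scatter.

Going from compound 3 to compound 4 `CC(=O)N1N=C(c2ccc3ccccc3c2)OC1c1ccncc1` puts pyridin-4-yl in place of 2-hydroxyphenyl on a saturated ring carbon. The three measured steps all touch this same aromatic group. Chloro in place of hydrogen gave a 1.0-fold lower number from compound 1 to compound 2 (0.01 log units; within the scatter) and hydroxy in place of hydrogen gave a 1.1-fold lower number from compound 1 to compound 3 (0.06 log units; within the scatter) while hydroxy in place of chloro gave a 1.1-fold lower number from compound 2 to compound 3 (0.05 log units; within the scatter) and so none of them moved the number beyond the scatter. For the measured compounds named here, none of these steps replaces a ring carbon with a hetero atom, so the data offer no direct precedent for this change, and the expectation rests on how flat these three compounds are. No step beyond the scatter is expected in this assay in either direction. The estimated step is a 1.2-fold higher number from compound 3 to compound 4 (0.07 log units; within the scatter) and the range around it is kept wide. Compound 4 is expected at 2.5 ug/mL (estimated range 1.3 ug/mL to 4.8 ug/mL).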

Compound 4, half-maximal inhibitory concentration: 2.56 ug/mL
Compound 4: the middle estimate sits 1.0-fold (0.01 log units) below what was measured, within the range that was stated.
By their numbers in this assay, from the lowest: compounds 3, 2, 1 and 4 (each within the scatter of the next).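

In this assay, pyridin-4-yl on the saturated ring carbon gives a 1.2-fold higher number from compound 3 to compound 4 (0.08 log units; within the scatter) and a 1.1-fold higher number from compound 2 to compound 4 (0.04 log units; within the scatter) and also a 1.1-fold higher number from compound 1 to compound 4 (0.02 log units; within the scatter), so all three steps stay within the scatter. The earlier compounds shown here varied only a small group on an aromatic ring of carbon only, whereas this change brings a hetero atom into the ring itself and, measured against compound 3, also removes the hydrogen-bond donor of 2-hydroxyphenyl. Among these four compounds, then, neither the change of ring nor the loss of that donor shifts the reading beyond the scatter, and nothing available explains why the reading stays so flat.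

From the compounds shown here alone, all four compounds carry an aromatic ring on this carbon, so it remains open whether the reading would stay flat with a saturated amine such as piperidine, a carboxylic acid or a longer alkyl chain there. The ring atom that bears an acetyl group is also the same throughout, which leaves open what a propanoyl or benzoyl group in its place would do.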